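The source may hold more compounds than are shown below. What is called first, only, known or untested is meant among the compounds shown, and "the series" means these compounds.

Measured so far in an assay on isolated protein for inhibition of leukotriene B4 receptor 1 (Homo sapiens), tested at 10 uM; a lower number here means less inhibition, a higher number more inhibition at the concentration tested (going by the name of the read-out):
compound 1, `CCc1cc(C(C)=O)c(O)cc1OCCCCC#N`: 92%
compound 2, `CCCCCc1cc(C(C)=O)c(O)cc1OCCCCC#N`: 31%
compound 3, `CCc1cc(C(C)=O)c(O)cc1OCCCCCCC#N`: 103%

Compound 3 stands highest of the three numbers in this assay. Its nearest neighbour is compound 1, the step of a number 11 percentage points higher from compound 1 to compound 3 (beyond the scatter) being modest; compound 2 lies far below both.

Compound 4, `C=CCc1cc(C(C)=O)c(O)cc1OCCCCCCC#N`, differs from compound 3 by vinyl in place of methyl on a saturated chain carbon bound to an aromatic carbon. The measured step that bears on this is a number 61 percentage points lower from compound 1 to compound 2 (beyond the scatter): it also enlarged the chain on the core that compound 4 enlarges, but by a longer saturated fragment, and it cost a large part of the inhibition. The step of a number 11 percentage points higher from compound 1 to compound 3 (beyond the scatter) concerns the nitrile-bearing chain and does not bear directly. With a single carbon entering as part of a vinyl group, a decrease of at most small size is expected in this assay, possibly none beyond the scatter; the expected step is a number 13 percentage points lower from compound 3 to compound 4 (beyond the scatter). For compound 4 the estimate in this assay is 90%, with a range from 70% to 105%.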

Compound 4, a percentage reported as inhibition, at one concentration (the size of the read-out at that concentration, not a potency): 97%
The estimate for compound 4 lay 7 percentage points below the measured number; measured number inside the range.
By their numbers in this assay, from the lowest: compound 2; then compounds 1, 4 and 3 (each within the scatter of the next, the first and the last beyond it).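

In this assay, ethyl to allyl on a saturated chain carbon bound to an aromatic carbon gives a number 6 percentage points lower from compound 3 to compound 4 (within the scatter), so at this position vinyl in place of methyl carries no step beyond the scatter. Among these compounds, the only earlier change at this position, a number 61 percentage points lower from compound 1 to compound 2 (beyond the scatter), was made with the nitrile chain of compound 1, and the new step shows that enlarging the group here does not cost inhibition in every case. No evidence is available to explain the new result.

Still open, as far as these compounds go, is how a propyl group in place of the allyl group of compound 4 would read, which would set a saturated chain against an unsaturated one with the same nitrile chain. Also open, from the compounds shown here alone, is how an amine or a carboxylic acid in place of the nitrile would read.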